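Working notes: from methoxy to azido in the series

The source may hold more compounds than are shown below. What is called first, only, known or untested is meant among the compounds shown, and "the series" means these compounds.

Measured compounds, values in a functional assay on HFF cells (Homo sapiens) for cytotoxicity; a lower number here means a stronger inhibitor, a higher number a weaker inhibitor
- compound 1 `CC(=O)OC1C(CF)OC(n2c(Cl)nc3cc(Cl)c(Cl)cc32)C1OC(C)=O` gives 32000 nM
- compound 2 `CSCC1OC(n2c(Cl)nc3cc(Cl)c(Cl)cc32)C(OC(C)=O)C1OC(C)=O` gives 32000 nM
- compound 3 `COC[C@H]1OC(n2c(Cl)nc3cc(Cl)c(Cl)cc32)[C@H](O)[C@@H]1O` gives 32000 nM

Compound 3 stands at 32000 nM in this assay and is level with compound 1 and compound 2 on these numbers. Compound 4 `[N-]=[N+]=NC[C@H]1OC(n2c(Cl)nc3cc(Cl)c(Cl)cc32)[C@H](O)[C@@H]1O` is the next entry, with azido in place of methoxy on a saturated chain carbon bound to a saturated ring carbon.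

One measured step falls at this place (no change at the digits printed from compound 1 to compound 2 (within the scatter)) and it is not beyond the scatter. Compound 1 and compound 2 also differ from compound 3 elsewhere in the structure, so this read-across is loose. Among these three compounds, fluoro, methylsulfanyl and methoxy on that chain carbon all give the same value, and none goes against this. Among the compounds with values here, no measured compound carries azido, so the data do not show how that group behaves here.

With compound 3 at 32000 nM as the starting point, no step beyond the scatter is expected in this assay and no direction is favoured. The expected step is small (no change at the digits printed from compound 3 to compound 4 (within the scatter)). For compound 4 the estimated value is 32000 nM (expected range 14000 nM to 70000 nM).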

Compound 4, half-maximal inhibitory concentration: 32000 nM
Compound 4: the middle estimate sits on the measured number at the digits printed, and the stated range covers the measured number.
By their numbers in this assay, from the lowest: compounds 1, 2, 3 and 4 (each within the scatter of the next).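

In this assay, within the data shown here, azido in place of methoxy on a saturated chain carbon bound to a saturated ring carbon gives no change at the digits printed from compound 3 to compound 4 (within the scatter), which is the first step at this place read with the rest of the structure identical to that of compound 3. The earlier step at this place, no change at the digits printed from compound 1 to compound 2 (within the scatter), belonged to a pair that differs from compound 3 elsewhere in the structure, so the flat reading no longer rests on that loose read-across alone and now extends to a group built only of nitrogen atoms. No measurement at hand bears on why the exchange of methoxy for azido leaves the reading level.

All four compounds read level, so the compounds shown do not tell whether any group on this chain carbon can move the value in this assay, and an amine, a carboxylic acid or a longer chain such as ethoxymethyl in place of methoxymethyl remains open. Also open, as far as these compounds go, is whether azido would read the same on the core of compound 1, which carries acetoxy groups.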